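Dropping the Methoxy: An Expectation for Compound 4

The source may hold more compounds than are shown below. What is called first, only, known or untested is meant among the compounds shown, and "the series" means these compounds.

Measured compounds:
- Compound 1 `COc1cccc(Nc2nccc(-c3cc(C)oc3C)n2)c1`: in a functional assay for inhibition, with Homo sapiens as the target (on this read-out higher numbers stand for weaker inhibition and lower numbers for stronger inhibition), compound 1 gives 5800 nM.
- Compound 2 `COc1cccc(Nc2nccc(-c3cccs3)n2)c1`: in this assay compound 2 gives 900 nM.
- Compound 3 `COc1cccc(Nc2nccc(-c3cccnc3)n2)c1`: in this assay compound 3 gives 300 nM.

Among these three numbers compound 2 stands second highest. Its nearest neighbour is compound 3, reached by the step of a 3.0-fold lower number from compound 2 to compound 3 (0.48 log units; beyond the scatter); its furthest is compound 1, from which it is separated by the step of a 6.4-fold lower number from compound 1 to compound 2 (0.81 log units; beyond the scatter).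

Compound 4 `c1ccc(Nc2nccc(-c3cccs3)n2)cc1` differs from compound 2 in a single place: hydrogen in place of methoxy on an aromatic carbon. Among the measured compounds shown here, none of the measured steps touches this place. Each of them, the large one a 19-fold lower number from compound 1 to compound 3 (1.29 log units; beyond the scatter) included, swaps the ring at the other end of the shared core while the methoxy is kept throughout. The measured data therefore give no direct guide to what removing the methoxy does. A step of modest size or none beyond the scatter is expected: a 1.4-fold higher number from compound 2 to compound 4 (0.16 log units; within the scatter). Compound 4 is estimated at 1300 nM, with a likely range from 500 nM to 3500 nM.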

Compound 4, half-maximal inhibitory concentration: 31700 nM
Estimate against measurement, compound 4: 24-fold (1.39 log units) below; the whole stated range lies below it.
By their numbers in this assay, from the lowest: compound 3; then compound 2; then compound 1; then compound 4.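

Replacing methoxy with hydrogen on this aromatic carbon, meta to a large group, gives a large loss of inhibition in this assay (a 35-fold higher number from compound 2 to compound 4 (1.55 log units; beyond the scatter)). Among the compounds shown here, the earlier compounds all kept the methoxy and varied only the ring at the other end of the shared core, so this is the first sign that the methoxy end also matters, with a step comparable in size to the largest ring swap (a 19-fold lower number from compound 1 to compound 3 (1.29 log units; beyond the scatter)). Nothing shown here explains why the methoxy counts for so much.

For the compounds shown here, the effect has been seen only with thiophen-2-yl on the core, so it remains open whether removing the methoxy costs as much in compound 3 or compound 1. Going by these compounds, it is also open whether ethoxy, hydroxy or an amine in the same place would keep the inhibition seen with methoxy.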